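Oxime ether isomer swap on the shared core

The source may hold more compounds than are shown below. What is called first, only, known or untested is meant among the compounds shown, and "the series" means these compounds.

Series notes. Compound 1 `c1ccc(-c2cnoc2)c(NCC2=NCCN2)c1`, compound 2 `c1ccc(-c2ccccc2NCC2=NCCN2)nc1` and compound 3 `CCO/N=C(\C)c1ccccc1NCC1=NCCN1` share one core and differ only in the group on the aromatic carbon. In a functional assay for activation of Alpha-1B adrenergic receptor (Homo sapiens), read by calcium flux (on this read-out higher numbers stand for an effect only at larger amounts of compound and lower numbers for an effect already at smaller amounts), compound 2 gives 30.2 nM. For compound 1 the assay reports only a limit, < 100000 nM, which is the limit of < 100000 nM in this assay, at which 1 of the 3 values shown sits. For compound 3 likewise only a limit is reported, < 5020 nM, which is the limit of < 5020 nM in this assay, at which 1 of the 3 values shown sits. The steps a step that the limit leaves unreadable from compound 1 to compound 2, a step that the two limits leave unreadable from compound 1 to compound 3 and a step that the limit leaves unreadable from compound 2 to compound 3 therefore cannot be sized, and compound 3 stands among the numbers shown as a limit only.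

Compound 4 `CC/C(=N\OC)c1ccccc1NCC1=NCCN1` differs from compound 3 by a group of 6 heavy atoms (4 carbon, 1 nitrogen, 1 oxygen; no ring) in place of a group of 6 heavy atoms (4 carbon, 1 nitrogen, 1 oxygen; no ring), on an aromatic carbon; the two have the same atoms, joined differently. Among the measured compounds shown here, no measured step covers this exchange, and the two steps ending at compound 3 are unreadable, so in this assay no step beyond the usual scatter is expected for this change, with the caution that the anchor is a limit. Compound 4 is expected to give 800 nM, with a range from 80 nM to 5000 nM. The estimated step is a step that the limit leaves unreadable from compound 3 to compound 4.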

Compound 4, half-maximal effective concentration: < 100000 nM
Compound 4: a limit, no number; the forecaster's own chance of this, stated with the estimate: 40%; the middle value lies beyond the limit too.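

In this assay compound 4 gives only a limit, so its steps to compound 1, compound 2 and compound 3 cannot be read. The compounds shown leave open whether exchanging the oxime ether of compound 3 for that of compound 4 shifts the read-out at all.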